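Hydroxyphenyl Shift on a Core Bearing Pyridin-2-yl

The compounds below may be only part of what the source reports. "The series", "measured", "known", "first", "only" and "open" are said of these compounds alone.

Three compounds of one series were examined in an assay on isolated protein for inhibition of DNA topoisomerase 1 (Homo sapiens), with a stated time of 30 min, tested at 100 uM; a lower number here means a weaker effect, a higher number a stronger effect of the compound at the concentration tested. Compound 1 `Oc1ccc(-c2cc(-c3cccs3)cc(-c3cccc(O)c3)n2)cc1` gives 85.7% in this assay, and compound 2 `Oc1ccc(-c2cc(-c3cccs3)cc(-c3ccc(O)cc3)n2)cc1` gives 86.3%. Between them lies a single change, (4-hydroxyphenyl in place of 3-hydroxyphenyl on an aromatic carbon), and the step in this assay is a number 0.6 percentage points higher from compound 1 to compound 2 (within the scatter). Compound 3 `Oc1ccc(-c2cc(-c3ccccn3)cc(-c3cccc(O)c3)n2)cc1` differs from compound 1 by pyridin-2-yl in place of thiophen-2-yl on an aromatic carbon; in this assay compound 3 gives 2.4%, and the step is a number 83.3 percentage points lower from compound 1 to compound 3 (beyond the scatter), the largest movement among the three. Compound 4 `Oc1ccc(-c2cc(-c3ccccn3)cc(-c3ccc(O)cc3)n2)cc1` has not yet been measured in this assay. It arises from compound 3 by 4-hydroxyphenyl in place of 3-hydroxyphenyl on an aromatic carbon, the same kind of change as that from compound 1 to compound 2. The surroundings are not identical: in the earlier pair the place is meta to a thiophen-2-yl group, whereas in the new pair it is meta to a pyridin-2-yl group, and how the two cores differ is given above by the change from compound 1 to compound 3. Since the earlier step was within the scatter, a step of about a number 1.6 percentage points higher from compound 3 to compound 4 (within the scatter) in this assay is expected for compound 4, resting on the step from compound 1 to compound 2 and on the low value of compound 3. For compound 4 a value of about 4% is estimated, with a range from 0% to 18%, and the measurement will decide.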

Compound 4, a percentage reported as inhibition, at one concentration (the size of the read-out at that concentration, not a potency): 1.4%
Compound 4: the middle estimate sits 2.6 percentage points above what was measured, within the range that was stated.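

In this assay, moving from 3-hydroxyphenyl to 4-hydroxyphenyl on the core bearing pyridin-2-yl gives a step of a number 1 percentage points lower from compound 3 to compound 4 (within the scatter), and this change reads the same on the two cores: the same change on two cores in this assay, a number 0.6 percentage points higher (within the scatter) from compound 1 to compound 2 and a number 1 percentage points lower (within the scatter) from compound 3 to compound 4, 1.6 percentage points apart, within the scatter of two such steps. Pyridin-2-yl in place of thiophen-2-yl, now taken with two 4-hydroxyphenyl groups on the shared core, gives a step of a number 84.9 percentage points lower from compound 2 to compound 4 (beyond the scatter), and this exchange also carries over between the two hydroxyphenyl arrangements: the same change on two cores in this assay, a number 83.3 percentage points lower (beyond the scatter) from compound 1 to compound 3 and a number 84.9 percentage points lower (beyond the scatter) from compound 2 to compound 4, 1.6 percentage points apart, within the scatter of two such steps. Within these four compounds, the hydroxyphenyl shift therefore carries from one core to the other without a measurable difference, but it does not recover what the pyridin-2-yl exchange removes, and the pair of steps shows neither how the shift would behave on any further core nor anything about potency, since each read-out comes from one concentration.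

The compounds shown leave open whether the high values of compound 1 and compound 2 are specific to thiophen-2-yl or would also be seen with another group at that place, such as furan-2-yl, phenyl or pyridin-3-yl. They also leave open what the hydroxyl groups contribute, which a methoxy group or an amine in their place could test.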